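Replacing a naphthalenyloxy group with a bromophenoxy group

The source may report more compounds than this note shows. Statements on the series, on what has been measured and on what is new or still open speak of the compounds shown alone.

Measured compounds:
compound 1, `Cc1nc2ccccc2c(=O)n1/N=C/c1ccc(Oc2ccc(Br)cc2)cc1`, 4.64
compound 2, `CCCc1nc2ccccc2c(=O)n1/N=C/c1ccc(Oc2ccc3ccccc3c2)cc1`, 6.12

In a physicochemical assay for lipophilicity, in phosphate buffer, measured as octanol-water partition (a lower number here means a more polar compound, a higher number a more lipophilic compound), compound 2 stands highest of the two numbers, and compound 1 lies a good way lower, beyond the usual scatter. Compound 3, `CCCc1nc2ccccc2c(=O)n1/N=C/c1ccc(Oc2ccc(Br)cc2)cc1`, has not yet been measured. It differs from compound 2 in one place: 4-bromophenyl in place of naphthalen-2-yl on an oxygen on an aromatic ring. For this change a downward step is expected in this assay, of moderate size rather than within the scatter. The step from compound 2 to compound 3 is estimated at a number 0.42 log units lower from compound 2 to compound 3 (beyond the scatter). Compound 3 is accordingly expected to give about 5.7, in the range 5.2 to 6.2.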

Compound 3, partition coefficient: 5.88
Estimate against measurement, compound 3: 0.18 log units below, within the range that was stated.
By their numbers in this assay, from the lowest: compound 1; then compounds 3 and 2 (each within the scatter of the next).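

In this assay, 4-bromophenyl in place of naphthalen-2-yl on an oxygen on an aromatic ring gives a number 0.24 log units lower from compound 2 to compound 3 (within the scatter), so this pair cannot be told apart here. Ethyl in place of hydrogen on a saturated chain carbon bound to an aromatic carbon gives a number 1.24 log units higher from compound 1 to compound 3 (beyond the scatter), so among these compounds the change on the chain, not the one on the oxygen, carries a step beyond the scatter. No evidence bears on the cause of either step. Still open, going by these compounds, is how an amine or a carboxylic acid in place of 4-bromophenyl would read, and whether a longer chain would extend the step seen on the chain.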